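Acyl ester series: from isobutyl to pyridin-4-yl

The source may report more compounds than this note shows. Statements on the series, on what has been measured and on what is new or still open speak of the compounds shown alone.

Measured in a functional assay on NCI-H460 cells (Homo sapiens) for cytotoxicity, read by MTT assay, with a stated time of 48 h; on this read-out lower numbers stand for stronger inhibition and higher numbers for weaker inhibition
- compound 1 `C=C1C(=O)O[C@H]2CC3=C[C@H](C/C(C)=C/[C@@H](OC(=O)C4CCC(F)(F)CC4)[C@H]12)OC3=O` reads > 10000 nM as a limit of the assay
- compound 2 `C=C1C(=O)O[C@H]2CC3=C[C@H](C/C(C)=C/[C@@H](OC(=O)CC(C)C)[C@H]12)OC3=O` reads 3800 nM

The result for compound 1 is a limit and not a number. Among the measured compounds shown here, compound 2 at 3800 nM is therefore the only true number so far. Compound 3 `C=C1C(=O)O[C@H]2CC3=C[C@H](C/C(C)=C/[C@@H](OC(=O)c4ccncc4)[C@H]12)OC3=O` differs from compound 2 by pyridin-4-yl in place of isobutyl on a carbonyl carbon. For the measured compounds named here, one measured step bears on this place, an at least 2.6-fold lower number from compound 1 to compound 2 (0.42 log units; beyond the scatter), and it lies beyond the scatter. Compound 1 and compound 3 both carry a ring here where compound 2 has isobutyl. That single step, from a non-aromatic ring, is thin support, but it points away from compound 2 towards weaker inhibition. A modest rise is therefore expected, as the estimated 2.1-fold higher number from compound 2 to compound 3 (0.32 log units; beyond the scatter). For compound 3 the estimated value is 8000 nM, with an expected range of 3500 nM to 10000 nM.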

Compound 3, half-maximal inhibitory concentration: 5600 nM
For compound 3 the middle estimate is 1.4-fold (0.15 log units) above the measured one; low and high end bracket the measured number.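

With pyridin-4-yl in place of isobutyl on the carbonyl carbon, the reading in this assay stays within the scatter: a 1.5-fold higher number from compound 2 to compound 3 (0.17 log units; within the scatter). A six-membered aromatic ring with a hetero atom is therefore accepted at this place as well as the open isobutyl chain, so a ring here does not by itself bring a reading to the limit, and the other comparison gives an at least 1.7-fold lower number from compound 1 to compound 3 (0.25 log units; that floor lies within the scatter). The result for compound 1 is a limit and not a number, so the true distance between the two rings stays unknown: the limit of > 10000 nM in this assay, at which 1 of the 3 values shown sits.

Open, from the compounds shown here alone, is whether phenyl, the same ring without its nitrogen, would read like compound 3. Also open, going by these compounds, is how an amine, a carboxylic acid or a longer chain on this carbonyl carbon would compare with compound 2 and compound 3.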